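Moving the acid closer on the benzyl group

This account rests on a few compounds, and the source may have more. Where it says the series, first, only, none or still open, it means among the compounds named here.

Of the compounds shown here, two of a shared core have been tested in a functional assay on HEK293 cells for agonist activity at Bile acid receptor (Homo sapiens); a lower number here means a smaller maximal response, a higher number a larger maximal response. Compound 1 `CC(C)c1onc(-c2c(Cl)cccc2Cl)c1COc1ccc(NCc2ccc(C(=O)O)cc2)c(C(F)(F)F)n1` gives 48% in this assay. Compound 2 `CC(C)c1onc(-c2c(Cl)cccc2Cl)c1COc1ccc(N(C)Cc2ccc(CCC(=O)O)cc2)c(C(F)(F)F)n1` gives 55% in this assay. The two numbers lie within the usual scatter of each other, so on these two numbers alone neither compound stands apart from the other; compound 2 is simply the reference point for the next change.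

Compound 3 `CC(C)c1onc(-c2c(Cl)cccc2Cl)c1COc1ccc(N(C)Cc2cccc(C(=O)O)c2)c(C(F)(F)F)n1` has not yet been measured. It differs from compound 2 in one place: 3-carboxyphenyl in place of 4-(2-carboxyethyl)phenyl on a saturated chain carbon bound to a nitrogen on an aromatic ring. Cut one bond further out, the same difference reads 4-(2-carboxyethyl)benzyl to 3-carboxybenzyl. Within the data shown here, no measured pair shows what a change of this kind does in this assay, so the direction of the step is not known from the data.

Without such a pair, a small step is the most plausible expectation, and the estimated move a number 10 percentage points lower from compound 2 to compound 3 (within the scatter) stays within the scatter. Compound 3 is therefore expected to give about 45% in this assay, most likely between 25% and 65%.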

Compound 3, largest response reached (reported as efficacy), in percent of the reference or control that the assay uses: 89%
Compound 3: middle estimate off by 44 percentage points, on the low side; the measured number lies above the stated range.
By their numbers in this assay, from the lowest: compounds 1 and 2 (each within the scatter of the next); then compound 3.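

In this assay the place on a saturated chain carbon bound to a nitrogen on an aromatic ring proves sensitive to which acid-bearing group it carries: 3-carboxyphenyl in place of 4-(2-carboxyethyl)phenyl gives a number 34 percentage points higher from compound 2 to compound 3 (beyond the scatter) and counts as a large step. Compound 1 and compound 2 had stood within the scatter of each other, so their different groups gave no sign that this part of the molecule could move the maximal response so far, yet (3-carboxybenzyl)(methyl)amino in place of (4-carboxybenzyl)amino gives a number 41 percentage points higher from compound 1 to compound 3 (beyond the scatter) and is also a large step. Nothing measured here accounts for the rise.

The step from compound 1 alters both the methyl on the nitrogen and the carboxybenzyl group, so a (4-carboxybenzyl)(methyl)amino or a (3-carboxybenzyl)amino group would be needed to tell these two contributions apart. From the compounds shown here alone, it also stays open whether the gain in compound 3 belongs to the 3-carboxy placement or to the shorter link to the acid, which a 3-(2-carboxyethyl)benzyl group would help to separate.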